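The source may hold more compounds than are shown below. What is called first, only, known or untested is meant among the compounds shown, and "the series" means these compounds.

Measured compounds: compound 1, `ClCc1ccc(Cn2cnc3c(Cl)ncnc32)cc1`, gives 2340 nM; compound 2, `ClCc1cccc(Cn2cnc3c(Cl)nc(Cl)nc32)c1`, gives 2180 nM; compound 3, `Nc1nc(Cl)c2ncn(Cc3ccccc3CCl)c2n1`, gives 18200 nM.

In a functional assay on SF-539 cells (Homo sapiens) for cytotoxicity, read by sulforhodamine B assay, with a stated time of 48 h (a higher number here means a weaker inhibitor of growth, a lower number a stronger inhibitor of growth), compound 1 holds the second highest of the three numbers. Compound 2 sits within the scatter of it, so no order between them can be read, while compound 3 gives a clearly higher number, a gap beyond the scatter. The unmeasured compound 4, `ClCc1ccc(Cn2cnc3c(Cl)nc(Cl)nc32)cc1`, differs from compound 1 by chloro in place of hydrogen on an aromatic carbon. Among the measured compounds shown here, no measured pair tracks this exact change, so the expectation leans on compound 2, which carries two chloro groups on the core and gives 2180 nM. The step from compound 1 to compound 4 is expected to be a 1.2-fold lower number from compound 1 to compound 4 (0.07 log units; within the scatter), not beyond the scatter. Compound 4 is estimated at 2000 nM, with a range from 800 nM to 5000 nM.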

Compound 4, concentration for 50% growth inhibition: 17000 nM
Beside the measured number, compound 4's estimate is 8.5-fold (0.93 log units) below it; measured number above the stated range.
By their numbers in this assay, from the lowest: compounds 2 and 1 (each within the scatter of the next); then compounds 4 and 3 (each within the scatter of the next).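

In this assay, the step is a 7.3-fold higher number from compound 1 to compound 4 (0.86 log units; beyond the scatter) and shows that chloro on this aromatic carbon, between two ring nitrogen atoms, is not a neutral change on the core of compound 1. Compound 2 carries the same chloro and gives 2180 nM while differing from compound 4 only in where the chloromethyl group sits, so among these compounds the effect of this chloro goes with that placement. Nothing measured here explains this rise. As far as these compounds go, whether fluoro, methyl or methoxy at this carbon would also raise the number remains open.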